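Thiophene in Place of Furan on the Tert-Butyl Ester

The source may report more compounds than this note shows. Statements on the series, on what has been measured and on what is new or still open speak of the compounds shown alone.

compound 1, `CC1=C(C(=O)OCC(C)C)C(c2ccco2)NC(=S)N1`: 7%
compound 2, `CC1=C(C(=O)OC(C)(C)C)C(c2ccco2)NC(=S)N1`: 3%
compound 3, `CC1=C(C(=O)OCc2ccccc2)C(c2ccco2)NC(=S)N1`: 32%

In an assay on membranes from CHO cells for displacement of a labelled ligand from adenosine receptor A1 (Homo sapiens), read by scintillation counting, with a stated time of 60 min, tested at 1 uM (on this read-out higher numbers stand for more inhibition at the one concentration tested (going by the name of the read-out) and lower numbers for less inhibition), compound 2 stands lowest of the three numbers. Its nearest neighbour is compound 1, with a number 4 percentage points lower from compound 1 to compound 2 (within the scatter), and its furthest is compound 3, with a number 29 percentage points higher from compound 2 to compound 3 (beyond the scatter). Compound 4, `CC1=C(C(=O)OC(C)(C)C)C(c2cccs2)NC(=S)N1`, differs from compound 2 by thiophen-2-yl in place of furan-2-yl on a saturated ring carbon. Among the compounds with values here, none of the measured steps touches this ring: all three change the ester group, namely a number 4 percentage points lower from compound 1 to compound 2 (within the scatter), a number 25 percentage points higher from compound 1 to compound 3 (beyond the scatter) and a number 29 percentage points higher from compound 2 to compound 3 (beyond the scatter). They therefore give no direct guidance, and the expected step in this assay is none beyond the scatter. Compound 4 is estimated at 6%, with a range from -6% to 22%. This expectation corresponds to a number 3 percentage points higher from compound 2 to compound 4 (within the scatter).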

Compound 4, a percentage reported as inhibition, at one concentration (the size of the read-out at that concentration, not a potency): 22%
Beside the measured number, compound 4's estimate is 16 percentage points below it; the range from low to high includes it.
By their numbers in this assay, from the lowest: compounds 2 and 1 (each within the scatter of the next); then compounds 4 and 3 (each within the scatter of the next).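

In this assay, within the data shown here, the earlier compounds changed only the ester, whereas thiophen-2-yl in place of furan-2-yl gives a number 19 percentage points higher from compound 2 to compound 4 (beyond the scatter) on the tert-butyl ester. The saturated ring carbon is therefore also a place where the read-out responds, even to a change of ring oxygen to sulfur that leaves the counts of heavy atoms, donors and acceptors as they were. Nothing at hand accounts for this step. From the compounds shown here alone, what a phenyl or a pyridin-3-yl group would give on this carbon remains open. So does whether thiophen-2-yl would give a similar step on the benzyl ester of compound 3.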